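A few compounds are considered here, and "the series" means these few. Any claim that something is new, unique, unknown or untested is made for them only; others in the source may bear on it.

Measured so far:

Compound 1 `CC(C)(C)n1nc(Oc2cc(O)ccn2)c2c(N)ncnc21` — in an ADME assay on microsomes from liver (Mus musculus) for metabolic stability, read by LC-MS, using NADPH, with a stated time of 10 min, tested at 10 uM (a lower number here means that the compound disappears faster, a higher number that the compound lasts longer), compound 1 gives 0.617 h.
Compound 2 `N#Cc1ccnc(Oc2nn(C3CCC3)c3ncnc(N)c23)c1` — in this assay compound 2 gives 0.4 h.
Compound 3 `Nc1ncnc2c1c(Oc1cc(C(F)(F)F)ccn1)nn2[C@H]1CC[C@@H](CO)CC1` — in this assay compound 3 gives 0.108 h.

All three share the same core and differ in the group on the pyridine ring and in the group on the aromatic nitrogen of the five-membered ring. Among the three numbers compound 3 stands lowest: its value lies beyond the usual scatter from that of compound 2, the nearest of the other two, and further still from that of compound 1. Compound 3 therefore disappears fastest of the three in this assay.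

The next compound, compound 4 `Nc1ncnc2c1c(Oc1cc(C(F)(F)F)ccn1)nn2[C@@H]1CCCC[C@H]1O`, keeps the trifluoromethyl-bearing pyridine of compound 3 and changes only the group on the aromatic nitrogen: 2-hydroxycyclohexyl in place of 4-(hydroxymethyl)cyclohexyl on an aromatic nitrogen. The group that enters is one heavy atom smaller and carries its hydroxyl directly on the ring rather than on a side chain.

Going by the values given here, no pair of measured compounds shows this kind of change on its own, so there is nothing in the measured set to fix the size of the step. The change is small, and the step from compound 3 to compound 4 in this assay is expected to be small too, most likely within the scatter, with no clear direction. The estimate for compound 4 in this assay is 0.13 h, in the range 0.05 h to 0.35 h, which means an expected step of a 1.2-fold higher number from compound 3 to compound 4 (0.08 log units; within the scatter).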

Compound 4, half-life: 1.1 h
Estimate against measurement, compound 4: 8.5-fold (0.93 log units) below, outside the stated range (above it).
By their numbers in this assay, from the lowest: compound 3; then compounds 2, 1 and 4 (each within the scatter of the next, the first and the last beyond it).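

In this assay the group on the aromatic nitrogen turns out to matter a great deal: with the trifluoromethyl-bearing pyridine kept, putting 2-hydroxycyclohexyl in place of 4-(hydroxymethyl)cyclohexyl gives a 10-fold higher number from compound 3 to compound 4 (1.01 log units; beyond the scatter) and the compound lasts much longer. The earlier compounds shown here differed in two places at once, so they could not show what this place does alone, whereas this pair differs only here. The two groups share a six-membered carbon ring and the same hydrogen-bond counts and differ by one heavy atom and by where the hydroxyl is carried, and nothing measured here explains why so modest a change in structure moves the half-life this far.

The compounds shown leave open which part of the change counts, the hydroxyl sitting directly on the ring, the loss of the side chain or the defined stereochemistry, and plain cyclohexyl or 4-hydroxycyclohexyl on the same nitrogen would help to separate these. From the compounds shown here alone, it also stays open whether the same swap would give a similar step with a nitrile on the pyridine instead of trifluoromethyl.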